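Swapping the heteroaryl at the ketone of a weak inhibitor

A few compounds are considered here, and "the series" means these few. Any claim that something is new, unique, unknown or untested is made for them only; others in the source may bear on it.

Measured compounds and values:
compound 1, `CC(C)c1cc(OCC(=O)[C@H](CC(=O)O)NC(=O)[C@@H](NC(=O)COc2cccc3ccccc23)C(C)C)no1` — > 200000 nM
compound 2, `CC(C)[C@H](NC(=O)COc1cccc2ccccc12)C(=O)N[C@@H](CC(=O)O)C(=O)CSc1ncc[nH]1` — > 200000 nM
compound 3, `CC(C)[C@H](NC(=O)COc1cccc2ccccc12)C(=O)N[C@@H](CC(=O)O)C(=O)CSc1nnc(-c2ccccc2)o1` — 150000 nM

These three compounds share one core and differ only in the group attached to the ketone at the end of the chain. In a functional assay on Jurkat cells (Homo sapiens) for inhibition (a higher number here means a weaker inhibitor, a lower number a stronger inhibitor), compound 1 reaches only the limit of the assay, > 200000 nM, and not a number. Compound 2 likewise reaches only a limit, > 200000 nM. Compound 3 gives a number, 150000 nM. Compound 1 and compound 2 sit at one and the same limit (the limit of > 200000 nM in this assay, at which 2 of the 3 values shown sit), and the number for compound 3 does not stand far from it.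

Compound 4, `CC(C)[C@H](NC(=O)COc1cccc2ccccc12)C(=O)N[C@@H](CC(=O)O)C(=O)COc1nncc(Cl)c1Cl`, is not yet measured. It differs from compound 2 in one place: (4,5-dichloropyridazin-3-yl)oxy in place of (1H-imidazol-2-yl)sulfanyl on a saturated chain carbon bound to a carbonyl carbon.

Among the compounds with values here, none of the measured steps makes this exact change. The step that the two limits leave unreadable from compound 1 to compound 2 cannot be read. The step of an at least 1.3-fold lower number from compound 2 to compound 3 (0.12 log units; that floor lies within the scatter) and the step of an at least 1.3-fold lower number from compound 1 to compound 3 (0.12 log units; that floor lies within the scatter) each have a floor that lies within the scatter. Nothing here points to a step beyond the scatter in either direction in this assay, and a limit is a real possibility again.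

Compound 4 is therefore expected to give about 200000 nM, estimated between 60000 nM and 700000 nM. The expected step is a number no higher from compound 2 to compound 4 (the limit leaves the size open).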

Compound 4, half-maximal inhibitory concentration: > 200000 nM
Compound 4 gave a limit, no number (the forecaster's own chance of this, stated with the estimate: 65%); the middle value sits exactly at the limit.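

In this assay compound 4 stops at a limit of the assay and gives no number, so a six-membered aromatic ring carrying two chlorines and held through oxygen brings no readable gain at this position. The only comparison with a number on one side is an at least 1.3-fold higher number from compound 3 to compound 4 (0.12 log units; that floor lies within the scatter), and the steps linking compound 4 to compound 1 and compound 2 cannot be read, so no change at this position has yet been shown to go beyond the scatter. Ring size, ring substituents and the linking atom have now all varied, yet compound 3 remains the only one of the four to give a number, and the rest share one ceiling: the limit of > 200000 nM in this assay, at which 3 of the 4 values shown sit.

The compounds shown leave open whether any group on this saturated chain carbon can bring the number far under that limit, for instance a plain phenoxy or a 2,3,5,6-tetrafluorophenoxy group. Within the data shown here, they also include no pair with the same ring on sulfur and on oxygen, so the effect of the linking atom cannot be separated from that of the ring.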